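Alkyne alcohol extension on two related cores

The compounds below may be only part of what the source reports. "The series", "measured", "known", "first", "only" and "open" are said of these compounds alone.

Measured compounds:
compound 1 `CCN(CC)CCNC(=O)C1CC(C(CC)(CC)c2ccc(C#CC(C)(O)CC)c(C)c2)=CN1CC` — 2780 nM
compound 2 `CCCC(O)(C#Cc1ccc(C(CC)(CC)C2=CN(CC)C(C(=O)NCCN(CC)CC)C2)cc1C)CCC` — 1290 nM
compound 3 `CCN(CC)CCNC(=O)C1CC=C(C(CC)(CC)c2ccc(C#CC(C)(O)CC)c(C)c2)N1CC` — 600 nM

In a functional assay on MCF7 cells (Homo sapiens) for antiproliferative activity, read by MTT assay, with a stated time of 24 h (on this read-out higher numbers stand for weaker inhibition and lower numbers for stronger inhibition), compound 1 gives 2780 nM, and compound 2 gives 1290 nM. The two differ by a group of 8 heavy atoms (7 carbon, 1 oxygen; no ring) in place of a group of 5 heavy atoms (4 carbon, 1 oxygen; no ring), on a triple-bonded carbon, and this change made a 2.2-fold lower number from compound 1 to compound 2 (0.33 log units; beyond the scatter).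

Compound 3 carries the same substituent on the triple-bonded carbon as compound 1 but on a core of the same atoms joined differently; the difference between the two cores is not broken down here. In this assay compound 3 gives 600 nM, the lowest of the three numbers, with compound 2 nearest and compound 1 furthest.

Compound 4 `CCCC(O)(C#Cc1ccc(C(CC)(CC)C2=CCC(C(=O)NCCN(CC)CC)N2CC)cc1C)CCC` has not been measured. It differs from compound 3 by a group of 8 heavy atoms (7 carbon, 1 oxygen; no ring) in place of a group of 5 heavy atoms (4 carbon, 1 oxygen; no ring), on a triple-bonded carbon, which is the same change as from compound 1 to compound 2, at a place described in identical terms, so the pair compound 3 to compound 4 is a second occurrence of that change on the other core.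

Compound 4 is expected to give 280 nM in this assay, a step of a 2.1-fold lower number from compound 3 to compound 4 (0.33 log units; beyond the scatter), because the same change gave a 2.2-fold lower number from compound 1 to compound 2 (0.33 log units; beyond the scatter). Compound 4 is estimated to fall between 120 nM and 700 nM. The range is kept wide: the change has been seen only once, and whether it carries over to the core of compound 3 is not known from these data.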

Compound 4, half-maximal inhibitory concentration: 1360 nM
Compound 4: middle estimate off by 4.9-fold (0.69 log units), on the low side; measured number above the stated range.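

In this assay, putting the group of 8 heavy atoms in place of 1-hydroxy-1-methylpropyl on the triple-bonded carbon gives a 2.3-fold higher number from compound 3 to compound 4 (0.36 log units; beyond the scatter), so on the core of compound 3 the step runs in the opposite direction to the one seen on the core of compound 1. The change therefore cannot be carried from one core to the other in this series as a fixed increment, and even its direction does not transfer: the same change on two cores in this assay, a 2.2-fold lower number (0.33 log units; beyond the scatter) from compound 1 to compound 2 and a 2.3-fold higher number (0.36 log units; beyond the scatter) from compound 3 to compound 4, 4.9-fold (0.69 log units) apart, beyond the scatter of two such steps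

This shows that the effect of the change depends on the core for these two pairs, but it does not show which feature of the cores is responsible, and with one pair on each core it does not show how reproducible either step is or whether the reversal is general.

Still open, from the compounds shown here alone, is how a substituent of another kind on the triple-bonded carbon, such as an amine, a carboxylic acid or a longer chain, would behave on the two cores. Also open, going by these compounds, is whether a group of intermediate size, such as a chain lying between the two compared here, would show the same split between the cores.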